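Reversing the phenyl-to-semicarbazide swap on the quinoline-amine scaffold

A few compounds are considered here, and "the series" means these few. Any claim that something is new, unique, unknown or untested is made for them only; others in the source may bear on it.

Measured compounds:
Compound 1, `COc1cc(NC(C)CCCNC(=O)NNC(=O)Nc2ccc(Br)cc2)c2ncccc2c1`: 101000 nM
Compound 2, `COc1cc(NC(C)CCCNC(=O)Nc2ccc(O)cc2)c2ncccc2c1`: 70000 nM
Compound 3, `COc1cc(NC(C)CCCNC(=O)Nc2cccc(Cl)c2)c2ncccc2c1`: 17000 nM

Of the compounds shown here, three sharing the same core have been tested in a functional assay on HeLa cells (Homo sapiens) for inhibition, read by MTT assay, with a stated time of 72 h; a lower number here means a stronger inhibitor, a higher number a weaker inhibitor. Compound 3 gives the lowest number of the three: compound 2 sits a 4.1-fold lower number from compound 2 to compound 3 (0.61 log units; beyond the scatter) away, and compound 1 is the furthest, at a 5.9-fold lower number from compound 1 to compound 3 (0.77 log units; beyond the scatter). The step between compound 1 and compound 2 is a 1.4-fold lower number from compound 1 to compound 2 (0.16 log units; within the scatter).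

Compound 4, `COc1cc(NC(C)CCCNC(=O)NNC(=O)Nc2ccc(Cl)cc2)c2ncccc2c1`, has not yet been measured. It differs from compound 3 at one place: ((4-chlorophenyl)carbamoyl)amino in place of 3-chlorophenyl on an amide-type nitrogen. The step from compound 1 to compound 3 is the one that bears on this change, since it runs the other way: there, a ((4-bromophenyl)carbamoyl)amino group giving way to 3-chlorophenyl brought the modest improvement of a 5.9-fold lower number from compound 1 to compound 3 (0.77 log units; beyond the scatter). Going back from the aryl to the carbamoylamino group, now with chlorine rather than bromine on the ring, is therefore expected to cost roughly as much in the same assay, and compound 4 is expected to land near compound 1 rather than near compound 3. Compound 4 is accordingly estimated at 90000 nM, within a range of 35000 nM to 230000 nM, which corresponds to an expected step of a 5.3-fold higher number from compound 3 to compound 4 (0.72 log units; beyond the scatter).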

Compound 4, half-maximal inhibitory concentration: 120000 nM
Compound 4: middle estimate off by 1.3-fold (0.12 log units), on the low side; low and high end bracket the measured number.
By their numbers in this assay, from the lowest: compound 3; then compounds 2, 1 and 4 (each within the scatter of the next).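

In this assay the cost of the carbamoylamino group now appears with chlorine as well as bromine on the ring: the change brings a 7.1-fold higher number from compound 3 to compound 4 (0.85 log units; beyond the scatter) and so is not tied to the bromo group of compound 1. The halogen itself makes no clear difference here, since chloro in place of bromo gives a 1.2-fold higher number from compound 1 to compound 4 (0.07 log units; within the scatter) and stays within the scatter. The hydroxyphenyl group does not separate from this group either, at a 1.7-fold higher number from compound 2 to compound 4 (0.23 log units; within the scatter), so only 3-chlorophenyl stands apart at this amide-type nitrogen.

As far as these compounds go, the step from compound 3 changes both the group and the place of chlorine on the ring, and whether 4-chlorophenyl or ((3-chlorophenyl)carbamoyl)amino would behave like 3-chlorophenyl remains open. Nothing available explains the difference.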